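This account rests on a few compounds, and the source may have more. Where it says the series, first, only, none or still open, it means among the compounds named here.

Measured so far: compound 1 `Cc1ccc(C)c(-n2nncc2CN2C(=O)C3(C(C#N)=C(N)Oc4c(N)cc5nc6ccccc6nc5c43)c3ccccc32)c1`, compound 2 `N#CC1=C(N)Oc2c(N)cc3nc4ccccc4nc3c2C12C(=O)N(Cc1cnnn1-c1cc(Cl)ccc1Cl)c1ccccc12`, compound 3 `N#CC1=C(N)Oc2c(N)cc3nc4ccccc4nc3c2C12C(=O)N(Cc1cnnn1-c1ccc(Cl)cc1[N+](=O)[O-])c1ccccc12`.

In a functional assay on A549 cells (Homo sapiens) for antiproliferative activity, read by MTT assay, with a stated time of 48 h (a higher number here means a weaker inhibitor, a lower number a stronger inhibitor), compound 1 gives > 50000 nM, a limit of the assay rather than a number. Compound 2 gives 10900 nM in this assay. Compound 3 gives > 50000 nM in this assay, again a limit. Compound 3 thus sits at the limit of > 50000 nM in this assay, at which 2 of the 3 values shown sit, alongside compound 1, and compound 2 alone has a number. Within the measured set there is an at least 4.5-fold lower number from compound 1 to compound 2 (0.66 log units; beyond the scatter), and an at least 4.5-fold higher number from compound 2 to compound 3 (0.66 log units; beyond the scatter); the remaining pair gives a step that the two limits leave unreadable from compound 1 to compound 3.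

Compound 4 `N#CC1=C(N)Oc2c(N)cc3nc4ccccc4nc3c2C12C(=O)N(Cc1cnnn1-c1c(Cl)cc(Cl)cc1Cl)c1ccccc12` is the next member: 2,4,6-trichlorophenyl in place of 4-chloro-2-nitrophenyl on an aromatic nitrogen. The change removes the nitro group that entered in the step from compound 2 to compound 3 and returns to a phenyl carrying chlorine only, as in compound 2. The step from compound 2 to compound 3 was at least modest and upward, so the reverse direction is expected here: compound 4 is expected to give a number below the limit, an at least 3.3-fold lower number from compound 3 to compound 4 (0.52 log units; beyond the scatter), near compound 2. The estimate for compound 4 in this assay is 15000 nM, expected to fall between 5000 nM and 50000 nM.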

Compound 4, half-maximal inhibitory concentration: > 50000 nM
Compound 4 was reported as a limit; the forecaster's own chance of this, stated with the estimate: 35%; middle value at least 3.3-fold (0.52 log units) away from the limit.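

In this assay compound 4 gives > 50000 nM, a limit of the assay and not a number. Losing the nitro group is therefore not enough to recover a measurable value, and a phenyl carrying chlorine only does not guarantee one: going from 2,5-dichlorophenyl to 2,4,6-trichlorophenyl gives an at least 4.5-fold higher number from compound 2 to compound 4 (0.66 log units; beyond the scatter), so the chlorine pattern on this ring counts, not merely the presence of chlorine. The steps to compound 4 from compound 1 and from compound 3 cannot be read, and most of the series now rests at a single ceiling: the limit of > 50000 nM in this assay, at which 3 of the 4 values shown sit.

Which of the chlorines in compound 4 accounts for the loss stays open, as does the order among compound 1, compound 3 and compound 4. Also open, as far as these compounds go, is how an unsubstituted phenyl, a 4-methoxyphenyl or a benzyl would behave at this position.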